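Swapping the pyridinyl on the triazole nitrogen for a benzodioxinyl

The source may report more compounds than this note shows. Statements on the series, on what has been measured and on what is new or still open speak of the compounds shown alone.

The shared core carries a triazole whose ring nitrogen bears an aryl or benzyl group. Compound 1 `O[C@H](COCCOC[C@@H](O)Cc1cn(Cc2cccc(-c3ccccc3)c2)nn1)Cc1ccc(-c2ccccc2)cc1` carries a biphenylmethyl there; in a functional assay on SGC-7901 cells (Homo sapiens) for inhibition, read by MTT assay, with a stated time of 72 h (a higher number here means a weaker inhibitor of growth, a lower number a stronger inhibitor of growth), compound 1 gives 10600 nM. Compound 2 `O[C@H](COCCOC[C@@H](O)Cc1cn(-c2cccnc2)nn1)Cc1ccc(-c2ccccc2)cc1` carries a pyridin-3-yl directly on the ring nitrogen, and in this assay compound 2 gives 29800 nM, the higher of the two numbers, the gap to compound 1 lying beyond the scatter.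

Compound 3 `O[C@H](COCCOC[C@@H](O)Cc1cn(-c2ccc3c(c2)OCCO3)nn1)Cc1ccc(-c2ccccc2)cc1` differs from compound 2 in one place: 2,3-dihydro-1,4-benzodioxin-6-yl in place of pyridin-3-yl on an aromatic nitrogen. The larger, oxygen-bearing aromatic group thus replaces the smaller pyridinyl on the same nitrogen. Among the compounds with values here, with only two measured compounds and no comparable step measured, the direction of this change is uncertain; a bulkier aryl on the triazole nitrogen is expected to move the number modestly downward, by a step near the edge of the scatter, since compound 1 with its larger group gives 10600 nM.

Compound 3 is therefore estimated at 16000 nM, within the range 6000 nM to 40000 nM, which means an expected step of a 1.9-fold lower number from compound 2 to compound 3 (0.27 log units; within the scatter).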

Compound 3, concentration for 50% growth inhibition: 6400 nM
Compound 3: middle estimate off by 2.5-fold (0.40 log units), on the high side; the measured number falls inside the stated range.
By their numbers in this assay, from the lowest: compounds 3 and 1 (each within the scatter of the next); then compound 2.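

The exchange of pyridin-3-yl for 2,3-dihydro-1,4-benzodioxin-6-yl gives the first single-place step measured on this aromatic nitrogen: in this assay, the change brings a 4.7-fold lower number from compound 2 to compound 3 (0.67 log units; beyond the scatter), so the number here does respond to the group carried at this position. It also places compound 3, whose group sits directly on the nitrogen, within the scatter of compound 1, which carries a biphenylmethyl there, so a group of the larger biphenylmethyl kind is not needed to reach that level among these compounds. No measurement shown bears on why the number moves.

Within the data shown here, the exchange alters several things at once, replacing a ring nitrogen with a carbon-only aromatic ring and adding a fused non-aromatic ring with two oxygens, so the single step cannot say which of these goes with the lower number. A plain phenyl or a methoxyphenyl on the same nitrogen would help separate them, and the compounds shown also leave open how an amine or a carboxylic acid on that aromatic ring would stand in this assay.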